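Swapping the aminophenyl arm for a chlorophenyl arm

This account rests on a few compounds, and the source may have more. Where it says the series, first, only, none or still open, it means among the compounds named here.

Of the compounds shown here, two built on one shared core have been measured in an assay for inhibition of MAP kinase-interacting serine/threonine-protein kinase 1 (Homo sapiens), read by luminescence and ADP-Glo, with a stated time of 2 h; a lower number here means a stronger inhibitor, a higher number a weaker inhibitor. Compound 1 `CC(=O)Nc1cccc(Cn2cc(-c3ccc4cn[nH]c4c3)ccc2=O)c1` gives 163 nM in this assay. Compound 2 `Nc1cccc(Cn2cc(-c3ccc4cn[nH]c4c3)ccc2=O)c1` gives 287 nM in this assay, and the change a 1.8-fold higher number from compound 1 to compound 2 (0.25 log units; within the scatter) is too small to rank the two. Compound 2 thus carries the higher of the two numbers, but within the scatter of compound 1.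

Compound 3 `O=c1ccc(-c2ccc3cn[nH]c3c2)cn1Cc1ccccc1Cl` differs from compound 2 by 2-chlorophenyl in place of 3-aminophenyl on a saturated chain carbon bound to an aromatic nitrogen. Going by the values given here, no measured step bears directly on this swap: the only step known, from compound 1 to compound 2, alters the group on the ring nitrogen that now leaves altogether, and it stayed within the scatter. With no guide of this kind, the step of a 1.0-fold higher number from compound 2 to compound 3 (0.02 log units; within the scatter) is expected to be modest in either direction. Compound 3 is therefore estimated at 300 nM in this assay, with a range from 90 nM to 1000 nM.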

Compound 3, half-maximal inhibitory concentration: 80 nM
Estimate against measurement, compound 3: 3.8-fold (0.57 log units) above; measured number below the stated range.
By their numbers in this assay, from the lowest: compound 3; then compounds 1 and 2 (each within the scatter of the next).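

In this assay, the swap at this position gives a 3.6-fold lower number from compound 2 to compound 3 (0.55 log units; beyond the scatter), so the aromatic arm on a saturated chain carbon bound to an aromatic nitrogen can shift the number by more than the scatter, which the change on the ring nitrogen of the arm did not do. It also shows that the hydrogen-bond donor and acceptor counted on 3-aminophenyl are not required for a lower number here, as 2-chlorophenyl has neither. Nothing available explains this drop.

Two things change together in this swap, the group on the ring and where it sits, and the compounds shown do not separate them. A plain phenyl arm, or a fluorine or a methyl group in place of the chlorine, would be needed to tell how much of the step belongs to the chlorine itself.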